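The source may hold more compounds than are shown below. What is called first, only, known or untested is meant among the compounds shown, and "the series" means these compounds.

Measured compounds:
compound 1 `CC(C(=O)NCc1ccc(Cl)cc1)c1ccc(NS(C)(=O)=O)c(F)c1`, 367 nM;
compound 2 `CC(C(=O)NCc1ccc(Br)cc1)c1ccc(NS(C)(=O)=O)c(F)c1`, 250 nM;
compound 3 `CC(C)c1ccc(CNC(=O)C(C)c2ccc(NS(C)(=O)=O)c(F)c2)cc1`, 144 nM.

In a functional assay on CHO cells for antagonist activity at transient receptor potential cation channel subfamily V member 1 (Rattus norvegicus) (a higher number here means a weaker inhibitor, a lower number a stronger inhibitor), compound 3 gives the lowest of the three numbers. Its step to compound 1, a 2.5-fold lower number from compound 1 to compound 3 (0.41 log units; beyond the scatter), is the only one beyond the scatter; the step of a 1.7-fold lower number from compound 2 to compound 3 (0.24 log units; within the scatter) is within it, as is a 1.5-fold lower number from compound 1 to compound 2 (0.17 log units; within the scatter). Compound 3 can therefore be set apart from compound 1 on these numbers, but not from compound 2.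

Compound 4 `CC(C(=O)NCCCc1ccc(Cl)cc1)c1ccc(NS(C)(=O)=O)c(F)c1` differs from compound 3 in one place: 2-(4-chlorophenyl)ethyl in place of 4-isopropylphenyl on a saturated chain carbon bound to an amide-type nitrogen. Two things change at once. The 4-chlorophenyl group returns, and on that part the step of a 2.5-fold lower number from compound 1 to compound 3 (0.41 log units; beyond the scatter) bears directly, read in reverse: a modest rise in the number is expected. Among the compounds with values here, the chain between the amide nitrogen and the ring also grows longer, and no measured pair shows what such a lengthening does. The expectation in this assay thus rests on the reversal alone, with a wide range to cover the unknown part. The step of a 3.5-fold higher number from compound 3 to compound 4 (0.54 log units; beyond the scatter) is expected to lie upward and outside the scatter. Compound 4 is estimated at 500 nM, within a range from 150 nM to 2500 nM.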

Compound 4, inhibition constant: 135 nM
Compound 4: middle estimate off by 3.7-fold (0.57 log units), on the high side; the measured number lies below the stated range.
By their numbers in this assay, from the lowest: compounds 4, 3, 2 and 1 (each within the scatter of the next, the first and the last beyond it).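

In this assay, within the data shown here, compound 1 and compound 4 form the first pair that speaks to the chain alone: the chlorine stays on the ring, 2-(4-chlorophenyl)ethyl stands in place of 4-chlorophenyl, and the result is a modest step beyond the scatter (a 2.7-fold lower number from compound 1 to compound 4 (0.43 log units; beyond the scatter)). With the longer chain, the chloro compound can no longer be set apart from the isopropyl compound (a 1.1-fold lower number from compound 3 to compound 4 (0.03 log units; within the scatter)) or from the bromo compound (a 1.9-fold lower number from compound 2 to compound 4 (0.27 log units; within the scatter)), so on this saturated chain carbon bound to an amide-type nitrogen, the length of the chain matters at least as much as the group on the ring among these compounds. Nothing at hand explains why the longer chain and the isopropyl group end up indistinguishable in this assay.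

The compounds shown leave open whether 2-(4-isopropylphenyl)ethyl or 2-(4-bromophenyl)ethyl would take the number lower still, or whether the two changes do not add up. They also leave open how a still longer chain, or an amine or ether oxygen placed within the chain, would read.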